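A few compounds are considered here, and "the series" means these few. Any claim that something is new, unique, unknown or untested is made for them only; others in the source may bear on it.

Measured so far:
- Compound 1, `CCOC(=O)C(C)Nc1cccc2c(S(=O)(=O)Nc3onc(C)c3C)cccc12`: 400 nM
- Compound 2, `Cc1noc(NS(=O)(=O)c2cccc3c(N(C)C)cccc23)c1Cc1ccccc1`: 50000 nM
- Compound 3, `Cc1noc(NS(=O)(=O)c2cccc3ccccc23)c1C`: 20000 nM

Compound 2 gives the highest number of the three in an assay on VSM-A10 cells for antagonist activity at Endothelin-1 receptor (Rattus norvegicus); a higher number here means a weaker inhibitor, a lower number a stronger inhibitor. Its nearest neighbour is compound 3, and the value of compound 2 lies furthest from that of compound 1. Going by the values given here, the only measured step between compounds differing in one place is a 50-fold higher number from compound 1 to compound 3 (1.70 log units; beyond the scatter), which is large but concerns a different position on the shared core, not the place changed here.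

Compound 4, `Cc1noc(NS(=O)(=O)c2cccc3c(N(C)C)cccc23)c1-c1ccccc1`, differs from compound 2 by phenyl in place of benzyl on an aromatic carbon. Among the compounds with values here, no measured step bears on this position, so the data give no direct guide to the direction; compound 3, carrying a methyl group there, and compound 2, carrying benzyl, differ only modestly. The step of a 1.7-fold lower number from compound 2 to compound 4 (0.22 log units; within the scatter) is therefore expected to be small. In this assay compound 4 is estimated at 30000 nM, with a range from 8000 nM to 150000 nM.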

Compound 4, half-maximal inhibitory concentration: 15900 nM
Compound 4: middle estimate off by 1.9-fold (0.28 log units), on the high side; low and high end bracket the measured number.
By their numbers in this assay, from the lowest: compound 1; then compounds 4 and 3 (each within the scatter of the next); then compound 2.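

In this assay, going by these compounds alone, the change from benzyl to phenyl gives a 3.1-fold lower number from compound 2 to compound 4 (0.50 log units; beyond the scatter), the first measured step at this aromatic carbon of the five-membered ring with 1 nitrogen and 1 oxygen. The result shows that this position responds to a small change in the group it carries: the entering and leaving groups each hold one six-membered aromatic ring of carbon only, and the heavy-atom count falls only from 7 to 6, yet the step lies beyond the scatter. No available evidence accounts for this shift.

On these data alone, how an amine, a carboxylic acid or a longer chain on this carbon would compare with phenyl and benzyl remains open. As far as these compounds go, it is also open whether a single step can separate the effect of the ring itself from that of the carbon linking it in benzyl.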